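Swapping the furan arm on the ring amine of compound 1

This account rests on a few compounds, and the source may have more. Where it says the series, first, only, none or still open, it means among the compounds named here.

Compound 1 `COc1cccc(-n2cc3nc(-c4cccnc4C)n(C[C@H]4CCCN(Cc5ccco5)C4)c(=O)c3n2)c1` gives 2.7 nM in an assay on HEK293 cells for displacement of a labelled ligand from growth hormone secretagogue receptor type 1 (Homo sapiens), with a stated time of 60 min (on this read-out lower numbers stand for stronger inhibition and higher numbers for weaker inhibition), the lower of the two numbers recorded; compound 2 `COc1ccc(-n2cc3nc(-c4ccccc4C)n(CC4CCCN(C(C)C)C4)c(=O)c3n2)cc1` gives 7.3 nM in this assay, and the two differ in several places, so only their values can be compared. Compound 3 `COc1cccc(-n2cc3nc(-c4cccnc4C)n(C[C@H]4CCCN(CC(C)C)C4)c(=O)c3n2)c1` differs from compound 1 by isopropyl in place of furan-2-yl on a saturated chain carbon bound to an amine nitrogen in a ring. Within the data shown here, since no single-change step is recorded, a small loss, at the edge of the scatter, is expected from compound 1 to compound 3, about a 1.7-fold higher number from compound 1 to compound 3 (0.22 log units; within the scatter). Compound 3 is therefore estimated at 4.5 nM, with a range from 1.5 nM to 13 nM.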

Compound 3, half-maximal inhibitory concentration: 5.7 nM
Compound 3: middle estimate off by 1.3-fold (0.10 log units), on the low side; measured number inside the range.
By their numbers in this assay, from the lowest: compound 1; then compounds 3 and 2 (each within the scatter of the next).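

Among these compounds, exchanging furan-2-yl for isopropyl on a saturated chain carbon bound to an amine nitrogen in a ring gives the first single-change step at this position: a 2.1-fold higher number from compound 1 to compound 3 (0.32 log units; beyond the scatter) in this assay. The step is modest, and with no ring on this arm compound 3 still gives 5.7 nM, so a low number here does not depend on the furan-2-yl ring. No measurement given here accounts for the step. The compounds shown leave open whether thiophen-2-yl or cyclopropyl at this place would stand with furan-2-yl or with isopropyl.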